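The source may hold more compounds than are shown below. What is called first, only, known or untested is meant among the compounds shown, and "the series" means these compounds.

Series values in a functional assay on HL-60 cells (Homo sapiens) for antiproliferative activity, read by CCK-8 assay, with a stated time of 72 h; on this read-out higher numbers stand for weaker inhibition and lower numbers for stronger inhibition:
- compound 1 `Cc1cc(Nc2cc(N3CCN(C)CC3)nc(Nc3ccc(S(N)(=O)=O)cc3)n2)n[nH]1`: 213 nM
- compound 2 `Cc1cc(Nc2cc(N3CCN(C)CC3)nc(Nc3cccc([N+](=O)[O-])c3)n2)n[nH]1`: 90.9 nM
- compound 3 `Cc1cc(Nc2cc(N3CCN(C)CC3)nc(Nc3cccc(Cl)c3)n2)n[nH]1`: not yet measured

Of the two measured compounds, compound 2 has the lower number, 90.9 nM. The next change is chloro in place of nitro on an aromatic carbon, meta to a large group: chloro in place of nitro on an aromatic carbon. Among the compounds with values here, only one measured step bears on it, a 2.3-fold lower number from compound 1 to compound 2 (0.37 log units; beyond the scatter), and that modest step replaced the whole substituted phenyl. Within the data shown here, no measured pair isolates this swap, so no step beyond the scatter is expected in this assay, and no direction is firmly indicated. The estimated step is a 1.1-fold lower number from compound 2 to compound 3 (0.06 log units; within the scatter). For compound 3 the expected value is 80 nM, with an estimated range of 30 nM to 220 nM.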

Compound 3, half-maximal inhibitory concentration: 131 nM
Beside the measured number, compound 3's estimate is 1.6-fold (0.21 log units) below it, within the range that was stated.
By their numbers in this assay, from the lowest: compounds 2, 3 and 1 (each within the scatter of the next, the first and the last beyond it).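

In this assay, exchanging nitro for chloro on this aromatic carbon gives a 1.4-fold higher number from compound 2 to compound 3 (0.16 log units; within the scatter), so the position tolerates this change, including the loss of the hydrogen-bond acceptors of nitro, with no separation between the two groups. Against the sulfamoyl compound, a 1.6-fold lower number from compound 1 to compound 3 (0.21 log units; within the scatter), so 3-chlorophenyl is not separated from 4-sulfamoylphenyl, whereas 3-nitrophenyl was. No supporting measurement accounts for either step.

Open, as far as these compounds go, is whether an amine or a carboxylic acid on this aromatic carbon would give a step beyond the scatter from compound 2. Also open, from the compounds shown here alone, is how group and ring position each contribute in the comparisons with compound 1.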